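The source may hold more compounds than are shown below. What is called first, only, known or untested is meant among the compounds shown, and "the series" means these compounds.

Measured in a functional assay on A549 cells (Homo sapiens) for inhibition, read by MTT assay, with a stated time of 72 h; on this read-out lower numbers stand for stronger inhibition and higher numbers for weaker inhibition:
- compound 1 `CC1=NN(c2ccccc2)C(=O)[C@]12C(=O)C=CC[C@H]2c1ccc(C)cc1`: 2890 nM
- compound 2 `CC1=NN(c2ccccc2)C(=O)[C@@]12C(=O)C=CC[C@H]2c1ccc(C)cc1`: 6090 nM

Compound 2 holds the higher of the two numbers. Compound 3 `CC1=NN(c2ccc(C)cc2)C(=O)[C@@]12C(=O)C=CC[C@H]2c1ccc(C)cc1` departs from compound 2 by methyl in place of hydrogen on an aromatic carbon, phenyl to 4-methylphenyl. Among the measured compounds shown here, the only measured step, a 2.1-fold higher number from compound 1 to compound 2 (0.32 log units; beyond the scatter), is modest and reflects (the fact that compounds 1 and 2 differ only in the configuration as drawn), so it sets a scale for this series but gives no direct reading on the methyl. A small step in this assay is therefore expected, with a slight lean towards a lower number and the direction uncertain. The expected value for compound 3 is 4500 nM, with an estimated range of 2000 nM to 10000 nM. The estimate means a 1.4-fold lower number from compound 2 to compound 3 (0.13 log units; within the scatter).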

Compound 3, half-maximal inhibitory concentration: 6790 nM
For compound 3 the middle estimate is 1.5-fold (0.18 log units) below the measured one; the range from low to high includes it.
By their numbers in this assay, from the lowest: compound 1; then compounds 2 and 3 (each within the scatter of the next).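

Methyl in place of hydrogen on the aromatic ring, para to a large group, gives no reading beyond the scatter in this assay (a 1.1-fold higher number from compound 2 to compound 3 (0.05 log units; within the scatter)). At this position, phenyl to 4-methylphenyl therefore leaves compound 3 level with compound 2, whereas the configuration step remains the only one beyond the scatter (a 2.1-fold higher number from compound 1 to compound 2 (0.32 log units; beyond the scatter)). Nothing at hand bears on the cause of the methyl result.

Open, from the compounds shown here alone, is whether methoxy, an amine or a carboxylic acid at this place would shift the number. Also open, going by these compounds, is whether 4-methylphenyl reads the same in the configuration of compound 1.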